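Aryl swap on the sulfonamide nitrogen: compound 4 expected

The source may hold more compounds than are shown below. What is called first, only, known or untested is meant among the compounds shown, and "the series" means these compounds.

Measured compounds:
compound 1, `Cc1ccccc1NS(=O)(=O)c1ccc(N2CCNC2=O)cc1`: 280 nM
compound 2, `O=C1NCCN1c1ccc(S(=O)(=O)Nc2ccc(F)c(F)c2)cc1`: 620 nM
compound 3, `CC(C)(C)c1cc(NS(=O)(=O)c2ccc(N3CCNC3=O)cc2)cc(C(C)(C)C)c1`: > 1000 nM (a limit)

The three measured compounds share one core and differ only in the aryl group on the sulfonamide nitrogen. In a functional assay on MCF7 cells (Homo sapiens) for antiproliferative activity, read by sulforhodamine B assay, with a stated time of 48 h (on this read-out lower numbers stand for stronger inhibition and higher numbers for weaker inhibition), compound 1 gives 280 nM. Compound 2 gives 620 nM, the highest of the two numbers available; its nearest neighbour is compound 1, and the step of a 2.2-fold higher number from compound 1 to compound 2 (0.35 log units; beyond the scatter). Compound 3 reaches only (the limit of > 1000 nM in this assay, at which 1 of the 3 values shown sits), which is a limit of the assay and not a number.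

Compound 4, `CCc1cccc(NS(=O)(=O)c2ccc(N3CCNC3=O)cc2)c1`, is not yet measured. It differs from compound 2 in one place: 3-ethylphenyl in place of 3,4-difluorophenyl on a sulfonamide nitrogen. Going by the values given here, the only measured step that bears on this change is the one from compound 1 to compound 2, where a 2.2-fold higher number from compound 1 to compound 2 (0.35 log units; beyond the scatter); moving back from a fluorinated aryl to an alkyl-bearing aryl is therefore expected to give a modest step toward a lower number, though compound 3, with two tert-butyl groups, warns that not every alkyl substitution follows compound 1. Compound 4 is thus estimated at 400 nM, within a range of 150 nM to 1200 nM. This expected step is a 1.6-fold lower number from compound 2 to compound 4 (0.19 log units; within the scatter).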

Compound 4, half-maximal inhibitory concentration: 130 nM
For compound 4 the middle estimate is 3.1-fold (0.49 log units) above the measured one; measured number below the stated range.
By their numbers in this assay, from the lowest: compound 4; then compound 1; then compound 2. At a limit, above all of these: compound 3.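

In this assay, the 3-ethylphenyl group gives the lowest number of the compounds that carry one, and the position on the sulfonamide nitrogen responds more strongly than the earlier step indicated: a 4.8-fold lower number from compound 2 to compound 4 (0.68 log units; beyond the scatter). The 3-ethylphenyl and 3,4-difluorophenyl groups have the same count of heavy atoms and neither has a hydrogen-bond donor or acceptor, so this step comes without a change in those counts; the 3-ethylphenyl group also improves on the other alkyl-bearing aryl group with a number in its own right, 2-methylphenyl, at a 2.2-fold lower number from compound 1 to compound 4 (0.33 log units; beyond the scatter). Compound 3, which also carries alkyl groups, goes against any simple reading that alkyl substitution lowers the number, but it stands at a limit of the assay and not at a number, and steps to it cannot be read: the limit of > 1000 nM in this assay, at which 1 of the 4 values shown sits.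

The compounds shown do not separate the effect of the ethyl group from that of its place on the aryl ring, and they give no reason for the step. Going by these compounds, whether a longer chain such as propyl, or an amine or a carboxylic acid on the aryl ring, would keep the number this low remains open.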